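A few compounds are considered here, and "the series" means these few. Any claim that something is new, unique, unknown or untested is made for them only; others in the source may bear on it.

Measured compounds:
- Compound 1, `COc1ccc(C(=O)/C=C/c2cc3ccccc3[nH]c2=O)cc1`: 7810 nM
- Compound 2, `O=C(/C=C/c1cc2ccccc2[nH]c1=O)c1ccc(O)cc1`: 4500 nM

Both compounds were tested in a functional assay on KM12 cells (Homo sapiens) for cytotoxicity, read by sulforhodamine B assay, with a stated time of 24 h; a higher number here means a weaker inhibitor of growth, a lower number a stronger inhibitor of growth. Compound 2 has the lower of the two numbers, but the step of a 1.7-fold lower number from compound 1 to compound 2 (0.24 log units; within the scatter) is within the scatter, so the two compounds cannot be told apart on these numbers.

Compound 3, `O=C(/C=C/c1cc2ccccc2[nH]c1=O)c1ccc(Cl)cc1`, has not yet been measured. It differs from compound 2 by chloro in place of hydroxy on an aromatic carbon. Within the data shown here, no measured step bears directly on this change: the only step on record, a 1.7-fold lower number from compound 1 to compound 2 (0.24 log units; within the scatter), swaps a methyl for a hydrogen on the oxygen at the same place and stays within the scatter. With nothing in hand that shows an effect at this position, a step of no size beyond the scatter is expected, a 1.1-fold higher number from compound 2 to compound 3 (0.05 log units; within the scatter). The estimate for compound 3 in this assay is therefore 5000 nM, with a range from 1800 nM to 14000 nM.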

Compound 3, concentration for total growth inhibition: 16300 nM
For compound 3 the middle estimate is 3.3-fold (0.51 log units) below the measured one; measured number above the stated range.
By their numbers in this assay, from the lowest: compounds 2 and 1 (each within the scatter of the next); then compound 3.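

In this assay, the substituent at this position does affect the number: a 3.6-fold higher number from compound 2 to compound 3 (0.56 log units; beyond the scatter), and a 2.1-fold higher number from compound 1 to compound 3 (0.32 log units; beyond the scatter), both modest but beyond the scatter, whereas the earlier swap between hydroxy and methoxy gave no readable change. Among these three compounds, the two with an oxygen attached at this position cannot be told apart, while compound 3, with chloro in its place, is the weakest inhibitor of growth. The data shown offer no explanation for this rise in the number.

From the compounds shown here alone, it remains open whether the rise comes from losing the oxygen or from adding the chlorine. A plain hydrogen, a fluoro group or an amine at this position would help separate those two readings.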